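The source may report more compounds than this note shows. Statements on the series, on what has been measured and on what is new or still open speak of the compounds shown alone.

Measured compounds:
- compound 1, `ClCc1ccc(Cn2cnc3c(Cl)ncnc32)cc1`: 3540 nM
- compound 2, `ClCc1ccc(Cn2cnc3nc(Cl)nc(Cl)c32)cc1`: 720 nM
- compound 3, `ClCc1ccc(Cn2cnc3c(Cl)nc(Cl)nc32)cc1`: 4370 nM

Of the compounds shown here, three built on closely related cores have been tested in a functional assay on OVCAR-3 cells (Homo sapiens) for cytotoxicity, read by sulforhodamine B assay, with a stated time of 48 h; a lower number here means a stronger inhibitor of growth, a higher number a weaker inhibitor of growth. In this assay compound 3 gives 4370 nM. Compound 1 differs from compound 3 by one change, (hydrogen in place of chloro on an aromatic carbon), and in this assay compound 1 gives 3540 nM. The step is a 1.2-fold lower number from compound 3 to compound 1 (0.09 log units; within the scatter), so these two compounds cannot be told apart by this measurement.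

Compound 2 has the same atoms as compound 3, joined differently; the difference between the two cores is not broken down here. In this assay compound 2 gives 720 nM, the lowest of the three numbers, and its gaps to both compound 1 and compound 3 lie beyond the usual scatter.

Compound 4, `ClCc1ccc(Cn2cnc3ncnc(Cl)c32)cc1`, is not yet measured. It differs from compound 2 by hydrogen in place of chloro on an aromatic carbon, the same change that separates compound 3 from compound 1. Because that earlier step was a 1.2-fold lower number from compound 3 to compound 1 (0.09 log units; within the scatter), the expectation is that compound 4 will also stay close to compound 2, with an estimated step of a 1.0-fold lower number from compound 2 to compound 4 (0.01 log units; within the scatter). The estimate for compound 4 in this assay is therefore 700 nM, expected to fall between 250 nM and 2000 nM, the width reflecting that the core of compound 2 is not the core on which the change was measured.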

Compound 4, concentration for total growth inhibition: 3380 nM
The estimate for compound 4 lay 4.8-fold (0.68 log units) below the measured number, and the stated range ends below it.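

In this assay, putting hydrogen in place of the chloro group on an aromatic carbon between two ring nitrogen atoms gives a 4.7-fold higher number from compound 2 to compound 4 (0.67 log units; beyond the scatter), so on the core of compound 2 this chloro group goes with a clear difference in the read-out. The same swap therefore does not carry over unchanged from one core to the other, and a step measured on one core is a poor guide to the step on the other: the same change on two cores in this assay, a 1.2-fold lower number (0.09 log units; within the scatter) from compound 3 to compound 1 and a 4.7-fold higher number (0.67 log units; beyond the scatter) from compound 2 to compound 4, 5.8-fold (0.76 log units) apart, beyond the scatter of two such steps. Within the data shown here, two pairs of compounds show only that the step can depend on the core, and they do not show why it does or what the swap would do on any further core.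

Going by these compounds, it remains open whether the lower number of compound 2 needs a chloro group on that carbon in particular, or whether an amine or a methoxy group there would give a similar result. On these data alone, all four compounds also carry the same chloromethyl group, so the effect of a longer chain or a carboxylic acid in its place remains open as well.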